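Swapping a Flexible Amine Tail for a Pyrrolidine Ring

A few compounds are considered here, and "the series" means these few. Any claim that something is new, unique, unknown or untested is made for them only; others in the source may bear on it.

Measured compounds:
- compound 1 `CN(C)CCCNc1nc(N)nc2cc(-c3ccc(C(F)(F)F)cc3)sc12` gives 148 ug/mL in a physicochemical assay for solubility, in phosphate buffer, at pH 6.5; a higher number here means a more soluble compound, a lower number a less soluble compound
- compound 2 `COc1nc(NCCCN(C)C)c2sc(-c3ccc(C(F)(F)F)cc3)cc2n1` gives < 5 ug/mL in this assay, which is a limit of the assay rather than a number

Compound 1 holds the only actual number shown in this assay. Among the compounds with values here, the only measured step, an at least 29-fold lower number from compound 1 to compound 2 (1.47 log units; beyond the scatter), is the sole guide to how changes move this read-out, and it ends at the limit of < 5 ug/mL in this assay, at which 1 of the 2 values shown sits.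

Compound 3 `Nc1nc(NC2CCNC2)c2sc(-c3ccc(C(F)(F)F)cc3)cc2n1` differs from compound 1 by pyrrolidin-3-yl in place of 3-(dimethylamino)propyl on a nitrogen on an aromatic ring. Within the data shown here, the methoxy-for-amino step sits at a different place on the shared core, so it does not bear directly on this change, and no measured step does. In this assay compound 3 is therefore expected to stay close to compound 1, with the step of a 1.2-fold higher number from compound 1 to compound 3 (0.09 log units; within the scatter) estimated to lie within the scatter. The estimate for compound 3 is 180 ug/mL, with a range from 60 ug/mL to 500 ug/mL.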

Compound 3, solubility: 155 ug/mL
Beside the measured number, compound 3's estimate is 1.2-fold (0.06 log units) above it, within the range that was stated.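

In this assay, within the data shown here, this is the first measured change on the nitrogen on the aromatic ring, and the step is a 1.0-fold higher number from compound 1 to compound 3 (0.02 log units; within the scatter). At this place, then, the open 3-(dimethylamino)propyl chain and the pyrrolidin-3-yl ring give numbers within the usual scatter of each other, so for this pair a ring can stand in for the chain without a measurable change in the read-out. Among these compounds, nothing measured so far explains why the two groups give such similar numbers.

On these data alone, whether the same holds for other groups on this nitrogen, such as a piperidine ring, a longer chain or a carboxylic acid, remains open. As far as these compounds go, it is also open whether pyrrolidin-3-yl would give a similar result with methoxy in place of amino on the shared core.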